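The source may hold more compounds than are shown below. What is called first, only, known or untested is meant among the compounds shown, and "the series" means these compounds.

Among the measured compounds shown here, in a functional assay on NCI-H460 cells (Homo sapiens) for antiproliferative activity, read by CCK-8 assay, with a stated time of 72 h (a higher number here means a weaker inhibitor, a lower number a stronger inhibitor), compound 1 (`Nc1ccccc1NC(=O)c1ccc(Cn2cnc3c(Nc4ccccc4)nc(Cl)nc32)cc1`) gives 5740 nM and compound 2 (`Nc1ccccc1NC(=O)c1ccc(Cn2cnc3c(NCc4ccccc4)nc(Cl)nc32)cc1`) gives 11200 nM on the same shared core, so compound 2 stands within the scatter of the only other number in hand. Compound 3 (`CC1CCN(c2nc(Cl)nc3c2ncn3Cc2ccc(C(=O)Nc3ccccc3N)cc2)CC1`) is still unmeasured, with 4-methylpiperidin-1-yl in place of benzylamino on an aromatic carbon as its difference from compound 2: 4-methylpiperidin-1-yl in place of benzylamino on an aromatic carbon. For the measured compounds named here, one measured step bears on this place, a 2.0-fold higher number from compound 1 to compound 2 (0.29 log units; within the scatter) for benzyl in place of phenyl on a nitrogen on an aromatic ring, and it lies within the scatter. Going by the values given here, no measured compound carries a non-aromatic ring at this place, so the data set no direction, and no step beyond the scatter is expected in this assay here. The expected change is a 1.4-fold lower number from compound 2 to compound 3 (0.15 log units; within the scatter) with wide margins. The estimated value for compound 3 is 8000 nM (range 2500 nM to 25000 nM).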

Compound 3, half-maximal inhibitory concentration: 7400 nM
Estimate against measurement, compound 3: 1.1-fold (0.03 log units) above, within the range that was stated.
By their numbers in this assay, from the lowest: compounds 1, 3 and 2 (each within the scatter of the next).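

In this assay, among the compounds shown here, compound 3 is the only compound here with a non-aromatic ring at this position, and 4-methylpiperidin-1-yl in place of benzylamino gives a 1.5-fold lower number from compound 2 to compound 3 (0.18 log units; within the scatter), while in place of anilino it gives a 1.3-fold higher number from compound 1 to compound 3 (0.11 log units; within the scatter). The ring of carbon only and the hydrogen-bond donor counted for benzylamino can therefore both leave this position without a step beyond the scatter, so the three compounds show no dependence on an aromatic ring or on that donor here. No data at hand give a reason for this flat result.

From the compounds shown here alone, it remains open whether a morpholine ring, a piperazine ring or a small dimethylamino group at this position would produce a step beyond the scatter. Going by these compounds, the effect of replacing the chloro group with an amine on the shared core also remains open.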